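A few compounds are considered here, and "the series" means these few. Any claim that something is new, unique, unknown or untested is made for them only; others in the source may bear on it.

Measured in a functional assay, read by spectrophotometry, with a stated time of 20 min; on this read-out higher numbers stand for weaker inhibition and lower numbers for stronger inhibition:
compound 1, `COc1ccc(-c2oc3ccccc3c(=O)c2C)cc1`: 100 ug/mL
compound 2, `Cc1c(-c2ccc(F)cc2)oc2ccccc2c1=O`: 114 ug/mL
compound 3, `Cc1c(-c2ccccc2F)oc2ccccc2c1=O`: 208 ug/mL

Compound 2 and compound 1 differ at one place, (methoxy in place of fluoro on an aromatic carbon). That exchange gave a 1.1-fold lower number from compound 2 to compound 1 (0.06 log units; within the scatter), so on this evidence the two are not distinguished by this assay. Compound 3 and compound 2 are built from the same atoms joined differently; the difference between the two cores is not broken down here. Compound 3 carries the highest number of the three, but its gap to compound 2 lies within the scatter, and only its gap to compound 1 lies beyond it.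

Compound 4, `COc1ccccc1-c1oc2ccccc2c(=O)c1C`, is not yet measured. From compound 3 it differs by methoxy in place of fluoro on an aromatic carbon. This is the same kind of change as that from compound 2 to compound 1, not the same one: there the place is para to a large group, here it is ortho to a large group. Within the data shown here, only one instance of this exchange is measured, so the expectation rests on a single step. For compound 4 a step of about a 1.1-fold lower number from compound 3 to compound 4 (0.04 log units; within the scatter) is expected, because a 1.1-fold lower number from compound 2 to compound 1 (0.06 log units; within the scatter) was within the scatter and nothing measured here suggests a larger move. Compound 4 is therefore estimated at 190 ug/mL, with a range of 95 ug/mL to 400 ug/mL.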

Compound 4, half-maximal inhibitory concentration: 143 ug/mL
Beside the measured number, compound 4's estimate is 1.3-fold (0.12 log units) above it; the range from low to high includes it.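

In this assay, methoxy in place of fluoro, ortho to a large group, gave a 1.5-fold lower number from compound 3 to compound 4 (0.16 log units; within the scatter), and the two instances of this exchange do not differ: the same change on two cores in this assay, a 1.1-fold lower number (0.06 log units; within the scatter) from compound 2 to compound 1 and a 1.5-fold lower number (0.16 log units; within the scatter) from compound 3 to compound 4, 1.3-fold (0.11 log units) apart, within the scatter of two such steps

On these two cores, then, the exchange can be carried across without a distinguishable move in the number, and the step on one core is a fair guide to the step on the other. This does not show that the exchange has no effect, as steps this small cannot be told apart from repeat scatter, and two pairs say nothing about a third core or about other exchanges at these places.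

The compounds shown carry only fluoro or methoxy on this ring, so it remains open how an amine or a carboxylic acid at the same place would read in this assay. Also open, on these data alone, is whether a longer chain such as ethoxy or butoxy would stay as close to fluoro as methoxy does.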